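The compounds below may be only part of what the source reports. "The series", "measured", "known", "first", "only" and "open" are said of these compounds alone.

Compound 1, `CCNC(=O)Nc1nc2cc(-c3cnc(N4CCC(C)(C(=O)O)CC4)nc3)cc(-c3ccccn3)c2s1`, stands only at a limit on the numbers shown. In a physicochemical assay for solubility, read by turbidimetry, in phosphate buffer, with a stated time of 24 h, at pH 7.4 (on this read-out lower numbers stand for lower solubility and higher numbers for higher solubility), compound 1 gives > 800 ug/mL, which is a limit of the assay and not a number. Compound 2, `CCNC(=O)Nc1nc2cc(-c3cnc(N4CCC(C(=O)O)(C(F)(F)F)CC4)nc3)cc(-c3ccccn3)c2s1`, in this assay gives > 800 ug/mL, again a limit. Compound 3, `CCNC(=O)Nc1nc2cc(-c3cnc(N4CCC(C(=O)O)(S(C)(=O)=O)CC4)nc3)cc(-c3ccccn3)c2s1`, in this assay gives > 800 ug/mL, also a limit. The measured steps all run between limits: a step that the two limits leave unreadable from compound 1 to compound 2, a step that the two limits leave unreadable from compound 1 to compound 3 and a step that the two limits leave unreadable from compound 2 to compound 3, so none of them has a readable size. What they share is the limit of > 800 ug/mL in this assay, at which 3 of the 3 values shown sit. Compound 4, `CCNC(=O)Nc1nc2cc(-c3cnc(N4CCCC4(C)C(=O)O)nc3)cc(-c3ccccn3)c2s1`, has not been measured in this assay. It differs from compound 1 in one place: 2-carboxy-2-methylpyrrolidin-1-yl in place of 4-carboxy-4-methylpiperidin-1-yl on an aromatic carbon. The three measured steps bear on this change only in that each exchange on a saturated ring carbon has left the read-out at the same limit, and none of them shows how far a compound could fall before a number appears. In this assay compound 4 is therefore expected to sit at 800 ug/mL, within a range from 300 ug/mL to 800 ug/mL. The step this estimate means, a number no higher from compound 1 to compound 4 (the limit leaves the size open), is expected to be none beyond the scatter, while the limits leave it unreadable.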

Compound 4, solubility: > 800 ug/mL
Compound 4: only a limit was reported; the forecaster's own chance of this, stated with the estimate: 80%; the middle value lies on the limit itself.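

In this assay compound 4 gives > 800 ug/mL, which is a limit of the assay and not a number. Compound 1 also stands at a limit, so the step from compound 1 to compound 4 cannot be read. The compounds shown leave open how their read-outs would order, with nothing to separate them but this: the limit of > 800 ug/mL in this assay, at which 4 of the 4 values shown sit.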